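The compounds below may be only part of what the source reports. "The series", "measured", "known", "first", "only" and "open" are said of these compounds alone.

Measured in a functional assay on HCT-116 cells (Homo sapiens) for cytotoxicity, read by MTT assay; on this read-out lower numbers stand for stronger inhibition and higher numbers for weaker inhibition:
Compound 1, `CCOC(=O)Nc1ccc(S(=O)(=O)N2C[C@H](c3ccccc3)NC2=O)cc1C`: 70 nM.
Compound 2, `CCOC(=O)Nc1c(C)cc(S(=O)(=O)N2C[C@H](c3ccccc3)NC2=O)cc1C`: > 10000 nM, which is a limit of the assay and not a number.
Compound 3, `CCOC(=O)Nc1ccc(S(=O)(=O)N2C(=O)N[C@@H](c3ccccc3)C2C)cc1C`: 5500 nM.

Compound 1 holds the lowest of the two numbers reported in this assay; the nearest measured step is a 79-fold higher number from compound 1 to compound 3 (1.90 log units; beyond the scatter). Compound 2 sits at the limit of > 10000 nM in this assay, at which 1 of the 3 values shown sits.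

Compound 4, `CCOC(=O)Nc1ccc(S(=O)(=O)N2C[C@H](c3ccccc3)NC2=O)c(C)c1C`, is not yet measured. Its difference from compound 1 is methyl in place of hydrogen on an aromatic carbon. Within the data shown here, two measured steps bear on this change. A methyl added on an aromatic carbon of the same ring gave an at least 140-fold higher number from compound 1 to compound 2 (2.15 log units; beyond the scatter). A methyl added on a saturated ring carbon gave a 79-fold higher number from compound 1 to compound 3 (1.90 log units; beyond the scatter). Both methyl additions seen so far in the series, on either ring, moved the number up by a large margin, and no compound shown points the other way. For compound 4 a large step upward is therefore expected, a 43-fold higher number from compound 1 to compound 4 (1.63 log units; beyond the scatter), with a real chance that only a limit is reported. The estimate for compound 4 is 3000 nM, in a range from 300 nM to 20000 nM.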

Compound 4, half-maximal inhibitory concentration: 350 nM
Compound 4: the middle estimate sits 8.6-fold (0.93 log units) above what was measured, and the stated range covers the measured number.
By their numbers in this assay, from the lowest: compound 1; then compound 4; then compound 3. At a limit, above all of these: compound 2.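

In this assay, methyl in place of hydrogen on an aromatic carbon is not penalised equally across this ring: at the carbon ortho to a large group and ortho to a methyl group, the change gives a 5.0-fold higher number from compound 1 to compound 4 (0.70 log units; beyond the scatter), a modest step. On another aromatic carbon of the same ring, the same change gives an at least 140-fold higher number from compound 1 to compound 2 (2.15 log units; beyond the scatter), so the size of the step depends on the position. Compound 2 gives only a limit, not a number: the limit of > 10000 nM in this assay, at which 1 of the 4 values shown sits.

All three methyl additions shown still raise the number, and none of the compounds goes against this. Going by these compounds, whether a fluorine, a methoxy group or an amine on the carbon changed in compound 4 would give a step of similar size remains open, as does whether a longer chain there would be tolerated.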